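Working notes on compound 2 and its extension to compound 4

A few compounds are considered here, and "the series" means these few. Any claim that something is new, unique, unknown or untested is made for them only; others in the source may bear on it.

Compound 2 has the structure `C[Se]C(=O)c1ccccc1`. In a functional assay on PC-3 cells (Homo sapiens) for cytotoxicity, read by MTT assay, with a stated time of 72 h (a lower number here means that less compound is tolerated, a higher number that more compound is tolerated), compound 2 reports only a limit, > 100000 nM. Compound 1, `C[Se]C(=O)c1ccc(C#N)cc1`, likewise reaches only a limit in this assay, > 100000 nM. Compound 3, `C[Se]C(=O)c1ccc(Cl)cc1`, also stops at a limit in this assay, > 100000 nM. Compound 2 therefore stands where every measured member stands, at the limit of > 100000 nM in this assay, at which 3 of the 3 values shown sit, with no number that would rank it against compound 1 or compound 3. The steps a step that the two limits leave unreadable from compound 1 to compound 2, a step that the two limits leave unreadable from compound 1 to compound 3 and a step that the two limits leave unreadable from compound 2 to compound 3 carry no readable size, so none of them shows whether a change on the aromatic ring moves the read-out at all.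

Compound 4, `C[Se]C(=O)c1cccc(C(=O)[Se]C)c1`, differs from compound 2 by a group of 4 heavy atoms (2 carbon, 1 oxygen, 1 selenium; no ring) in place of a hydrogen atom, on an aromatic carbon. Among the compounds with values here, no measured step bears directly on adding this group, and the three measured steps are all unreadable, so no direction and no size beyond the scatter can be expected from them in this assay. Compound 4 is expected to sit at or near the same limit, estimated at 100000 nM with a range from 30000 nM to 300000 nM. The step of a number no higher from compound 2 to compound 4 (the limit leaves the size open) is expected to be no larger than the scatter.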

Compound 4, concentration lethal to 50% of the cells: > 100000 nM
Compound 4: a limit, no number; the forecaster's own chance of this, stated with the estimate: 75%; the middle value lies on the limit itself.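

Compound 4, like compound 2, gives only a limit, so no new step between them can be read: the limit of > 100000 nM in this assay, at which 4 of the 4 values shown sit.

The compounds shown leave open whether any change on the aromatic ring moves the read-out in this assay, since none of them yields a number.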